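Replacing an aryl amide with a carbamate-bearing pyrrolidine

A few compounds are considered here, and "the series" means these few. Any claim that something is new, unique, unknown or untested is made for them only; others in the source may bear on it.

Measured so far in an assay on isolated protein for displacement of a labelled ligand from secreted frizzled-related protein 1 (Homo sapiens), read by fluorescence polarization, with a stated time of 30 min; a lower number here means a stronger inhibitor, a higher number a weaker inhibitor:
Compound 1 `O=C(c1cccc(Cl)c1)N1CCC(NS(=O)(=O)c2cc(S(=O)(=O)c3ccccc3)ccc2C(F)(F)F)CC1`: 300 nM
Compound 2 `O=S(=O)(NC1CCN(S(=O)(=O)c2cccc(-c3nnn[nH]3)c2)CC1)c1cc(S(=O)(=O)c2ccccc2)ccc1C(F)(F)F`: 30 nM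
Compound 3 `O=C(O)c1ccc(N2CCC(NS(=O)(=O)c3cc(S(=O)(=O)c4ccccc4)ccc3C(F)(F)F)CC2)cc1`: 120 nM

Compound 1 has the highest number of the three. Compound 3 lies nearest to it, and the step of a 2.5-fold lower number from compound 1 to compound 3 (0.40 log units; beyond the scatter) replaced the whole aryl-carbonyl group. Compound 2 lies furthest from it. Compound 4 `CC(C)(C)OC(=O)N1CC[C@@H](C(=O)N2CCC(NS(=O)(=O)c3cc(S(=O)(=O)c4ccccc4)ccc3C(F)(F)F)CC2)C1` keeps the carbonyl of compound 1 and changes only what hangs on it: 1-(tert-butoxycarbonyl)pyrrolidin-3-yl in place of 3-chlorophenyl on a carbonyl carbon. Within the data shown here, no measured step changes just this group while keeping the carbonyl, so the two earlier steps give only a loose guide. A change no larger than the scatter in either direction is expected, and the estimated step of a 1.3-fold higher number from compound 1 to compound 4 (0.12 log units; within the scatter) reflects that. Compound 4 is therefore expected to give about 400 nM, with a range from 130 nM to 1200 nM.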

Compound 4, half-maximal inhibitory concentration: 50 nM
For compound 4 the middle estimate is 8.0-fold (0.90 log units) above the measured one; the measured number lies below the stated range.
By their numbers in this assay, from the lowest: compounds 2 and 4 (each within the scatter of the next); then compound 3; then compound 1.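

In this assay, the step of a 6.0-fold lower number from compound 1 to compound 4 (0.78 log units; beyond the scatter) shows that this place on the carbonyl carbon does not need an aromatic ring, since 1-(tert-butoxycarbonyl)pyrrolidin-3-yl stands in for 3-chlorophenyl and the number falls. The entering group has more heavy atoms, two hydrogen-bond acceptors and a defined stereocentre, so several features change at once and the step cannot be assigned to any one of them. No measurement shown here explains the gain. The compounds shown leave open how much of the step belongs to the tert-butoxycarbonyl group and how much to the pyrrolidine ring. A free amine on that ring's nitrogen would help separate the two.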